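The source may hold more compounds than are shown below. What is called first, only, known or untested is meant among the compounds shown, and "the series" means these compounds.

In a physicochemical assay for lipophilicity (on this read-out lower numbers stand for lower lipophilicity and higher numbers for higher lipophilicity), three compounds with different groups on the same amide-type nitrogen have been measured. Compound 1 `CNC(=O)c1cc(C(=O)NC2CCOCC2)n([C@@H](C)c2ccccc2)n1`, with oxan-4-yl, gives 3.6. Compound 2 `CNC(=O)c1cc(C(=O)NCCO)n([C@@H](C)c2ccccc2)n1`, with 2-hydroxyethyl, gives 2.4. Compound 3 `CNC(=O)c1cc(C(=O)N[C@H]2CC[C@H](O)CC2)n([C@@H](C)c2ccccc2)n1`, with 4-hydroxycyclohexyl, gives 2.9, which places it in the middle of the three.

Compound 4 `CNC(=O)c1cc(C(=O)N[C@H]2[C@@H]3C[C@@H](O)C[C@@H]32)n([C@@H](C)c2ccccc2)n1` has not yet been measured. The change from compound 3 is confined to that nitrogen: a group of 7 heavy atoms (6 carbon, 1 oxygen; one three-membered non-aromatic ring of carbon only, one five-membered non-aromatic ring of carbon only) in place of a group of 7 heavy atoms (6 carbon, 1 oxygen; one six-membered non-aromatic ring of carbon only), on an amide-type nitrogen. The six-membered ring gives way to one three-membered and one five-membered non-aromatic ring of carbon only.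

For the measured compounds named here, three measured steps bear on this change, all at the same nitrogen: a number 1.20 log units lower from compound 1 to compound 2 (beyond the scatter), a number 0.70 log units lower from compound 1 to compound 3 (beyond the scatter) and a number 0.50 log units higher from compound 2 to compound 3 (beyond the scatter). Going by the values given here, none of them is a direct precedent, since no measured pair keeps the same counted atoms while changing only the ring. The closest guide is a number 0.50 log units higher from compound 2 to compound 3 (beyond the scatter), but those two groups differ in carbon, whereas the groups in compound 3 and compound 4 do not. A large or modest step is therefore not expected in this assay, and no shift beyond the scatter is anticipated. The expected change is a number 0.10 log units lower from compound 3 to compound 4 (within the scatter). Compound 4 is estimated at 2.8, with an expected range of 2.4 to 3.2.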

Compound 4, distribution coefficient: 3.2
Compound 4: middle estimate off by 0.40 log units, on the low side; the measured number falls inside the stated range.
By their numbers in this assay, from the lowest: compound 2; then compounds 3 and 4 (each within the scatter of the next); then compound 1.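

In this assay, for the compounds shown here, the step at the amide-type nitrogen gives a number 0.30 log units higher from compound 3 to compound 4 (within the scatter) and is the first measured change that keeps the counted atoms, donor and acceptor of the group while replacing one six-membered non-aromatic ring of carbon only with one three-membered and one five-membered non-aromatic ring of carbon only. On this read-out the ring change does not separate the two groups, and the entering group stands apart from the other two groups at this nitrogen, with a number 0.80 log units higher from compound 2 to compound 4 (beyond the scatter) and with a number 0.40 log units lower from compound 1 to compound 4 (beyond the scatter) as well. No supporting data bear on why this ring change leaves the number within the scatter.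

Open, going by these compounds, is how the read-out responds at this nitrogen when an amine or a carboxylic acid stands in place of the hydroxyl on the same two-ring group. Also open, on these data alone, is whether other stereocentre arrangements of that group stay within the scatter of compound 4, and whether the match between compound 3 and compound 4 holds on any read-out other than this assay for this series.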